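The compounds below may be only part of what the source reports. "The series", "measured", "known", "first", "only" and "open" are said of these compounds alone.

Compound 1 `CC1CCN(C2CCN(S(=O)(=O)c3cccc(C(F)(F)F)c3)CC2)CC1` was tested in a functional assay on DLD-1 cells (Homo sapiens) for antiproliferative activity, read by CellTiter-Glo, with a stated time of 72 h (a higher number here means a weaker inhibitor, a lower number a stronger inhibitor), where it gave only a limit, > 5000 nM. Compound 2 `COc1cc(C)ccc1S(=O)(=O)N1CCC(N2CCC(C)CC2)CC1` gave in this assay only the limit > 5000 nM. Compound 3 `Cc1cc(C)c(S(=O)(=O)c2ccc(N3CCC(C)CC3)cc2)c(C)c1` gave in this assay only the limit > 5000 nM. Compound 1 thus stands at the limit of > 5000 nM in this assay, at which 3 of the 3 values shown sit, with no number by which to set it against the other two. Compound 4 `COc1cccc(S(=O)(=O)N2CCC(N3CCC(C)CC3)CC2)c1` differs from compound 1 by methoxy in place of trifluoromethyl on an aromatic carbon. Going by the values given here, no measured pair isolates this change. Compound 2 also carries a methoxy on its aryl ring, and in this assay compound 2 gives > 5000 nM. On that showing the step that the limit leaves unreadable from compound 1 to compound 4 is expected to be none beyond the scatter. Compound 4 is estimated at 9000 nM in this assay, ranging from 3000 nM to 30000 nM, and is expected to return a limit once more.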

Compound 4, half-maximal inhibitory concentration: > 5000 nM
Compound 4: a limit, no number (the forecaster's own chance of this, stated with the estimate: 80%); the middle value does not contradict the limit.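

Going by these compounds alone, compound 1 and compound 4 each return only a limit in this assay, so no step between them can be read. The compounds shown leave open what change to the shared core would give a measurable value: the limit of > 5000 nM in this assay, at which 4 of the 4 values shown sit.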